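The source may report more compounds than this note shows. Statements on the series, on what has been measured and on what is new or still open speak of the compounds shown alone.

In a functional assay on Fem-X cells (Homo sapiens) for cytotoxicity (on this read-out lower numbers stand for stronger inhibition and higher numbers for weaker inhibition), compound 1 `CC1=CCC[C@H]2[C@](C)(CC3=CC(=O)C=CC3=O)[C@@H](C)CC[C@]12C` gives 23900 nM as its reading. Compound 2 `CCCCSC1=CC(=O)C(C[C@]2(C)[C@@H](C)CC[C@]3(C)C(C)=CCC[C@@H]23)=CC1=O` with added butylsulfanyl reads 24400 nM and compound 3 `CC1=CCC[C@H]2[C@](C)(CC3=CC(=O)C(Sc4ccccc4)=CC3=O)[C@@H](C)CC[C@]12C` with added phenylsulfanyl reads 42500 nM so all three lie within the scatter of one another and compound 1 stands level with both. Compound 4 `CNC1=CC(=O)C=C(C[C@]2(C)[C@@H](C)CC[C@]3(C)C(C)=CCC[C@@H]23)C1=O` is still unmeasured. Its change from compound 1 is methylamino in place of hydrogen on a double-bonded ring carbon with methylamino in place of hydrogen on a double-bonded ring carbon, two ring bonds from the ring atom that bears a large group. The closest evidence is a 1.0-fold higher number from compound 1 to compound 2 (0.01 log units; within the scatter) for butylsulfanyl and a 1.8-fold higher number from compound 1 to compound 3 (0.25 log units; within the scatter) for phenylsulfanyl, and both stay within the scatter. Among the measured compounds shown here, no measured compound carries methylamino, so these steps are only a loose guide, and no step beyond the scatter is expected in this assay here. The expected change is a 1.1-fold lower number from compound 1 to compound 4 (0.04 log units; within the scatter) and it stays within the scatter. The estimate for compound 4 is 22000 nM with an expected range from 8000 nM to 55000 nM in a real measurement.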

Compound 4, half-maximal inhibitory concentration: 5200 nM
Compound 4: middle estimate off by 4.2-fold (0.63 log units), on the high side; the whole stated range lies above it.
By their numbers in this assay, from the lowest: compound 4; then compounds 1, 2 and 3 (each within the scatter of the next).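

In this assay, the step of a 4.6-fold lower number from compound 1 to compound 4 (0.66 log units; beyond the scatter) shows that methylamino, on a double-bonded ring carbon two ring bonds from the ring atom that bears a large group, can move the reading beyond the scatter towards stronger inhibition. Among the compounds shown here, the butylsulfanyl and phenylsulfanyl changes had not done this: a 1.0-fold higher number from compound 1 to compound 2 (0.01 log units; within the scatter) and a 1.8-fold higher number from compound 1 to compound 3 (0.25 log units; within the scatter) both stayed within the scatter, so compound 4 is the first sign that a change on this ring of the shared core can shift the reading. Nothing measured here explains the step.

Only one nitrogen group is shown at this place, so it remains open whether a longer amine such as butylamino or a ring-bearing one such as phenylamino would behave the same way. On these data alone, it is also open whether the step follows the nitrogen itself or the ring position, which an oxygen-linked group such as methoxy at this place could help to separate.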